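Chlorophenyl Isomer Step in a Small Agonist Series

A few compounds are considered here, and "the series" means these few. Any claim that something is new, unique, unknown or untested is made for them only; others in the source may bear on it.

Two members of the series have numbers in an assay on cells for agonist activity at probable G-protein coupled receptor 34 (Mus musculus), with a stated time of 1 h; a lower number here means a smaller maximal response, a higher number a larger maximal response. Compound 1 `Cc1ccc(Oc2cccc(COc3ccccc3CCC(=O)OCCCOP(=O)(O)OC[C@H](N)C(=O)O)c2)cc1` gives 18.2% in this assay. Among the measured compounds shown here, compound 2 `N[C@@H](COP(=O)(O)OCCCOC(=O)CCc1ccccc1OCc1cccc(Oc2cccc(Cl)c2)c1)C(=O)O` gives 17.1% in this assay, the lower of the two numbers, but the only measured step, a number 1.1 percentage points lower from compound 1 to compound 2 (within the scatter), stays within the scatter, so the two values cannot be ordered. Compound 3 `N[C@@H](COP(=O)(O)OCCCOC(=O)CCc1ccccc1OCc1cccc(Oc2ccc(Cl)cc2)c1)C(=O)O` is the next candidate; it differs from compound 2 by 4-chlorophenyl in place of 3-chlorophenyl on an oxygen on an aromatic ring. For the measured compounds named here, no measured step moves the chlorine on that ring, so the comparison rests on the one step that replaced the whole group on the same oxygen, a number 1.1 percentage points lower from compound 1 to compound 2 (within the scatter), which was itself within the scatter. The expected change, a number 0.1 percentage points lower from compound 2 to compound 3 (within the scatter), is therefore no step beyond the scatter. Compound 3 is estimated at 17%, with a range from 9% to 27% in this assay.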

Compound 3, largest response reached (Emax), in percent of the reference or control that the assay uses: 17.8%
Compound 3: middle estimate off by 0.8 percentage points, on the low side; the range from low to high includes it.
By their numbers in this assay, from the lowest: compounds 2, 3 and 1 (each within the scatter of the next).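

Moving the chlorine from 3-chlorophenyl to 4-chlorophenyl on this oxygen gives a number 0.7 percentage points higher from compound 2 to compound 3 (within the scatter) in this assay, so the place of the chlorine on this ring, tested here on its own for the first time, does not separate the two compounds. The earlier step changed the atom and its place together, whereas the comparison of 4-chlorophenyl with 4-methylphenyl isolates chloro in place of methyl on an aromatic carbon and gives a number 0.4 percentage points lower from compound 1 to compound 3 (within the scatter), so this exchange alone does not separate the compounds either. Nothing at hand offers an explanation for these results.

From the compounds shown here alone, all three compounds carry only a chloro or a methyl on this outer ring, so it stays open whether a nitrile, a methoxy or an amine there would step beyond the scatter. Going by these compounds, whether an unsubstituted phenyl on the same oxygen would do so also stays open.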